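The compounds below may be only part of what the source reports. "The series", "measured", "known", "first", "only" and "open" are said of these compounds alone.

Of the compounds shown here, three sharing one core have been measured in an ADME assay for permeability, using PAMPA, with a stated time of 4 h; on this read-out lower numbers stand for lower permeability and higher numbers for higher permeability. Compound 1, `Cc1ccc(Oc2ccc3nc(COc4cccc(C(=O)O)c4)n(C)c3n2)cc1F`, gives 14.8 10^-6 cm/s in this assay. Compound 2, `Cn1c(COc2cccc(C(=O)O)c2)nc2ccc(Oc3ccc4c(c3)CCC4)nc21`, gives 31.5 10^-6 cm/s in this assay. Compound 3, `Cn1c(COc2cccc(C(=O)O)c2)nc2ccc(Oc3ccc(Cl)cn3)cc21`, gives 16.2 10^-6 cm/s in this assay. Among these three numbers compound 3 stands second highest, and its gaps to compound 1 and to compound 2 both lie within the usual scatter. Going by the values given here, the only step between measured compounds that differ in one place is a 2.1-fold higher number from compound 1 to compound 2 (0.33 log units; beyond the scatter), a modest change brought about by exchanging the whole aryl group on the oxygen on an aromatic ring.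

Compound 4, `Cn1c(COc2cccc(C(=O)O)c2)nc2ccc(Oc3ncc(Cl)cc3F)cc21`, differs from compound 3 in one place: fluoro in place of hydrogen on an aromatic carbon. Among the compounds with values here, none of the measured compounds shows what adding a single fluorine to this ring does, so the one known step, which swaps entire groups, bears on the present change only loosely. Because even that larger exchange produced no more than a 2.1-fold higher number from compound 1 to compound 2 (0.33 log units; beyond the scatter), a single fluoro entering in place of hydrogen is expected to move this assay by a step no larger than a 1.1-fold higher number from compound 3 to compound 4 (0.05 log units; within the scatter), if at all beyond the scatter. Compound 4 is therefore estimated at 18 10^-6 cm/s, with a likely range from 10 10^-6 cm/s to 32 10^-6 cm/s.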

Compound 4, apparent permeability: 11.8 10^-6 cm/s
The estimate for compound 4 lay 1.5-fold (0.18 log units) above the measured number; the measured number falls inside the stated range.
By their numbers in this assay, from the lowest: compounds 4, 1, 3 and 2 (each within the scatter of the next, the first and the last beyond it).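

In this assay, fluoro in place of hydrogen on the 5-chloropyridin-2-yl group, on the carbon ortho to a large group and two atoms from the ring nitrogen, gives a 1.4-fold lower number from compound 3 to compound 4 (0.14 log units; within the scatter) and so stays inside the usual scatter. Going by these compounds alone, until now the only readable step was the exchange of one whole aryl group for another, whereas this result isolates a single added atom at one defined place on the ring and shows no change that can be told from repeat measurements, even though compound 4 and compound 2 lie beyond the scatter of each other by their printed values. No measurement given here accounts for this result.

What the compounds shown leave open is whether a larger group at this same carbon, such as methyl, methoxy or a nitrile, would move this read-out beyond the scatter, and whether fluoro on another carbon of the ring would behave as it does here. They also leave open whether the step would hold with an amide or a tetrazole in place of the carboxylic acid.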